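This account rests on a few compounds, and the source may have more. Where it says the series, first, only, none or still open, it means among the compounds named here.

In a functional assay on MGC-803 cells (Homo sapiens) for cytotoxicity, read by MTT assay, with a stated time of 2 days (on this read-out lower numbers stand for stronger inhibition and higher numbers for weaker inhibition), compound 1 `c1ccc(CO/N=C2/C(c3c[nH]c4ccccc34)=Nc3ccccc32)cc1` gives 15400 nM. Compound 2 `Cc1ccc(CO/N=C2/C(c3c[nH]c4ccccc34)=Nc3ccccc32)cc1` carries a methyl in place of a hydrogen on an aromatic carbon, and in this assay compound 2 gives 22800 nM. The step of a 1.5-fold higher number from compound 1 to compound 2 (0.17 log units; within the scatter) is small. Among the measured compounds shown here, of the two numbers so far, compound 2 holds the higher one, but its gap to compound 1 lies within the scatter, so nothing separates the two.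

Compound 3 `Fc1ccc(CO/N=C2/C(c3c[nH]c4ccccc34)=Nc3ccccc32)cc1` arises from compound 2 by fluoro in place of methyl on an aromatic carbon. For the measured compounds named here, only one measured step bears on this change, the exchange of hydrogen for methyl at that same carbon, a 1.5-fold higher number from compound 1 to compound 2 (0.17 log units; within the scatter), and it stayed within the scatter. A further swap at the same place, now methyl for fluoro, is therefore expected to move the number in this assay little or not at all beyond the scatter, with no direction to be read from the data. Compound 3 is expected to give 18000 nM in this assay, within a range from 7000 nM to 45000 nM. That corresponds to an expected step of a 1.3-fold lower number from compound 2 to compound 3 (0.10 log units; within the scatter).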

Compound 3, half-maximal inhibitory concentration: 33000 nM
The estimate for compound 3 lay 1.8-fold (0.26 log units) below the measured number; the range from low to high includes it.
By their numbers in this assay, from the lowest: compounds 1, 2 and 3 (each within the scatter of the next, the first and the last beyond it).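

In this assay, fluoro in place of methyl at this position gives a 1.4-fold higher number from compound 2 to compound 3 (0.16 log units; within the scatter), so the data do not separate these two groups. Fluoro in place of hydrogen on the same carbon, however, gives a 2.1-fold higher number from compound 1 to compound 3 (0.33 log units; beyond the scatter), which is the first step at this position to pass beyond the scatter; it is modest and points toward weaker inhibition, while compound 2 remains within the scatter of both neighbours and does not fall clearly on either side. No measurement here offers an explanation for this small shift.

Going by these compounds, the three compounds carry only hydrogen, methyl or fluoro on this aromatic carbon, para to a large group, so it remains open whether an amine, a carboxylic acid or a methoxy group at the same place would move the number further, and in which direction. On these data alone, it also remains open whether fluoro would give a similar step at another carbon of this six-membered aromatic ring or on the shared core.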